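This account rests on a few compounds, and the source may have more. Where it says the series, first, only, none or still open, it means among the compounds named here.

Measured compounds:
- compound 1, `CN(C)/[N+]([O-])=N/Oc1cc(O/N=[N+](\[O-])N2CCN(c3ncccn3)CC2)c([N+](=O)[O-])cc1[N+](=O)[O-]`: 5000 nM
- compound 2, `CN(C)/[N+]([O-])=N/Oc1cc(O/N=[N+](\[O-])N2CCCCC2)c([N+](=O)[O-])cc1[N+](=O)[O-]`: 4900 nM

The two measured compounds share one core and differ only in the amine attached to the second diazeniumdiolate group. In a functional assay on HL-60 cells (Homo sapiens) for antiproliferative activity, read by MTT assay, with a stated time of 72 h (on this read-out lower numbers stand for stronger inhibition of growth and higher numbers for weaker inhibition of growth), compound 1 gives 5000 nM and compound 2 gives 4900 nM. These two values lie within the usual scatter of each other, so neither compound can be placed ahead of the other on this read-out.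

Compound 3, `CN(C)/[N+]([O-])=N/Oc1cc(O/N=[N+](\[O-])N2CCCC2CO)c([N+](=O)[O-])cc1[N+](=O)[O-]`, has not yet been tested in this assay. It differs from compound 2 as follows: 2-(hydroxymethyl)pyrrolidin-1-yl in place of piperidin-1-yl on a double-bonded nitrogen. Going by the values given here, no step between measured compounds has been recorded for this kind of change, so there is nothing to anchor its size. Among the compounds with values here, since the one amine exchange that has been measured, between compound 1 and compound 2, produced no change beyond the scatter, the step of a 1.0-fold higher number from compound 2 to compound 3 (0.01 log units; within the scatter) is expected to be small and in no clear direction. Compound 3 is therefore estimated at 5000 nM, with a range from 2000 nM to 12000 nM.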

Compound 3, concentration for total growth inhibition: 2000 nM
Estimate against measurement, compound 3: 2.5-fold (0.40 log units) above; the range from low to high includes it.
By their numbers in this assay, from the lowest: compound 3; then compounds 2 and 1 (each within the scatter of the next).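

Exchanging piperidin-1-yl for 2-(hydroxymethyl)pyrrolidin-1-yl on a double-bonded nitrogen gives a 2.5-fold lower number from compound 2 to compound 3 (0.39 log units; beyond the scatter) in this assay and so shows that the amine at this position can move the read-out beyond the scatter, which the earlier pair of compound 1 and compound 2 did not show. The change replaces a six-membered ring with a five-membered ring and brings in a hydroxymethyl group at the same time, and this single step cannot separate the two. Nothing available here bears on the reason for the step.

The compounds shown leave open whether the step follows the ring or the hydroxymethyl group, which plain pyrrolidin-1-yl and a hydroxymethyl-bearing piperidin-1-yl would help to separate. They also leave open whether a hydroxyethyl chain or a carboxylic acid in place of the hydroxymethyl group would keep the step.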